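Benzyl in place of 4-fluorophenyl on the amide

The source may report more compounds than this note shows. Statements on the series, on what has been measured and on what is new or still open speak of the compounds shown alone.

In a functional assay on MDA-MB-468 cells (Homo sapiens) for inhibition, read by MTT assay (on this read-out higher numbers stand for weaker inhibition of growth and lower numbers for stronger inhibition of growth), compound 2 `CC1=C(/C=C/C(C)=C/C=C/C(C)=C\C(=O)Nc2ccc(F)cc2)C(C)(C)CCC1n1ccnc1` gives 4570 nM and compound 1 `CC1=C(/C=C/C(C)=C/C=C/C(C)=C\C(=O)NCc2cccc(F)c2)C(C)(C)CCC1n1ccnc1` gives 3090 nM, so the two stand within the scatter of each other. The change to compound 3 `CC1=C(/C=C/C(C)=C/C=C/C(C)=C\C(=O)NCc2ccccc2)C(C)(C)CCC1n1ccnc1` is benzyl in place of 4-fluorophenyl on an amide-type nitrogen. Within the data shown here, the one measured step bearing on it, a 1.5-fold higher number from compound 1 to compound 2 (0.17 log units; within the scatter), puts 4-fluorophenyl in place of 3-fluorobenzyl and stays within the scatter. No step beyond the scatter is therefore expected in this assay. The estimated step is a 1.3-fold lower number from compound 2 to compound 3 (0.10 log units; within the scatter). Compound 3 is expected at 3600 nM, within an estimated range of 1700 nM to 7500 nM.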

Compound 3, concentration for 50% growth inhibition: 7240 nM
Compound 3: the middle estimate sits 2.0-fold (0.30 log units) below what was measured, within the range that was stated.
By their numbers in this assay, from the lowest: compounds 1, 2 and 3 (each within the scatter of the next, the first and the last beyond it).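

Hydrogen in place of fluoro on the benzyl ring is the one change here that goes beyond the scatter in this assay (a 2.3-fold higher number from compound 1 to compound 3 (0.37 log units; beyond the scatter)), a modest step towards weaker inhibition of growth. Benzyl in place of 4-fluorophenyl on the amide-type nitrogen stays within it (a 1.6-fold higher number from compound 2 to compound 3 (0.20 log units; within the scatter)). No evidence at hand accounts for either step.

From the compounds shown here alone, whether this modest step is specific to fluoro stays open, and a chloro, methoxy or amine group on that aromatic carbon would test it. A phenethyl group on the amide-type nitrogen would extend the comparison to a longer chain.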